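The source may hold more compounds than are shown below. What is called first, only, known or untested is meant among the compounds shown, and "the series" means these compounds.

Compound 3, `NC1=NC2(CCSCC2)N(OCCCOc2cccc(Cl)c2Cl)C(N)=N1`, sits at the lower of the two numbers in an assay on isolated protein for inhibition of Dihydrofolate reductase (Homo sapiens), read by spectrophotometry, using NADPH, with stated times of 5 s and 6 min, tested at 5 uM (on this read-out higher numbers stand for a stronger effect at the one concentration tested and lower numbers for a weaker effect), where compound 3 gives 83.8%. Among the compounds with values here, the nearest number belongs to compound 1, `NC1=NC2(CCSCC2)N(OCCCOc2cccc(Cl)c2)C(N)=N1`, which in this assay gives 88.3%; the step of a number 4.5 percentage points lower from compound 1 to compound 3 (within the scatter) is the one measured step. Compound 2, `NC1=NC2(CCOCC2)N(OCCCOc2ccc(F)cc2)C(N)=N1`, is reported in this assay only as a limit, > 90%. That limit is the ceiling of the read-out, (the limit of > 90% in this assay, at which 1 of the 3 values shown sits), so the top of the scale is close to both measured numbers.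

Compound 4, `NC1=NC2(CCSCC2)N(OCCCOc2ccc(Cl)cc2)C(N)=N1`, is not yet measured in this assay. The change from compound 3 is 4-chlorophenyl in place of 2,3-dichlorophenyl on an oxygen on a saturated carbon. Within the data shown here, the one measured step that bears on a change at this aromatic ring is the step from compound 1 to compound 3, and it stayed within the scatter, so the series gives no sign that the number or placing of chloro groups on this ring moves the read-out by much. A step of no more than the scatter is therefore expected, with a number 2.2 percentage points higher from compound 3 to compound 4 (within the scatter) the expected step from compound 3 to compound 4.

Compound 4 is expected to give about 86% in this assay, within 76% to 92%, with a real chance that only the limit is reported.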

Compound 4, a percentage reported as inhibition, at one concentration (the size of the read-out at that concentration, not a potency): > 90%
Compound 4: no number, only a limit (the forecaster's own chance of this, stated with the estimate: 25%); middle value at least 4 percentage points from the limit.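

Within the data shown here, compound 4 is reported in this assay only as a limit, which is the first sign that a single chloro group at this position on the core of compound 1 can reach the top of the scale. The change to 4-chlorophenyl from 2,3-dichlorophenyl on an oxygen on a saturated carbon gives a number at least 6.2 percentage points higher from compound 3 to compound 4 (that floor lies within the scatter), and the change from 3-chlorophenyl gives a number at least 1.7 percentage points higher from compound 1 to compound 4 (that floor lies within the scatter), so neither step can be shown to exceed the usual scatter, and their true sizes cannot be read. The chlorophenyl position therefore remains without a measured ranking, and the read-out now offers less room to separate compounds at this concentration: the limit of > 90% in this assay, at which 2 of the 4 values shown sit.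

The compounds shown leave open how far 4-chlorophenyl truly stands from the other two chlorophenyl groups, since a limit gives only a floor for each step. They also leave open whether an amine or a carboxylic acid on this aromatic ring, or a longer chain between the ring and the core, would keep the read-out near the top of the scale or bring it clearly down.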